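This account rests on a few compounds, and the source may have more. Where it says the series, first, only, none or still open, it means among the compounds named here.

Measured in an assay on HEK293 cells for displacement of a labelled ligand from metabotropic glutamate receptor 5 (Homo sapiens), with a stated time of 2 h; a higher number here means a weaker inhibitor, a lower number a stronger inhibitor:
compound 1, `CC(C)N1CCc2nc(C#Cc3ccccc3)ccc2C1=O`: 1280 nM
compound 2, `O=C1c2ccc(C#Cc3ccccc3)nc2CCN1C1CCCC1`: 890 nM
compound 3, `COc1cccc(C#Cc2ccc3c(n2)CCN(C2CCCC2)C3=O)c1`: > 32000 nM

The value recorded for compound 3 is a limit of the assay and not a number: the limit of > 32000 nM in this assay, at which 1 of the 3 values shown sits. Of the two numbers, compound 2 carries the lower one, with compound 1 nearest, but the step of a 1.4-fold lower number from compound 1 to compound 2 (0.16 log units; within the scatter), an exchange of the substituent on the amide-type nitrogen in the ring, is within the scatter, so the two compounds are not separated. The step of an at least 35-fold higher number from compound 2 to compound 3 (1.55 log units; beyond the scatter) concerns a substituent on the aromatic ring and is large.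

Compound 4, `O=C1c2ccc(C#Cc3ccccc3)nc2CCN1C1CCCCC1`, differs from compound 2 in one place: cyclohexyl in place of cyclopentyl on an amide-type nitrogen in a ring. The step that bears on it is the other exchange at the same nitrogen, a 1.4-fold lower number from compound 1 to compound 2 (0.16 log units; within the scatter), which stayed within the scatter. The step from compound 2 to compound 3 sits at a different position and gives no guidance here. With a single comparable exchange at this nitrogen leaving this assay unmoved beyond the scatter, the step of a 1.0-fold lower number from compound 2 to compound 4 (0.02 log units; within the scatter) is expected to be small and in no firm direction. Compound 4 is estimated at 850 nM in this assay, with an expected range from 300 nM to 2500 nM.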

Compound 4, inhibition constant: 12400 nM
Compound 4: the middle estimate sits 15-fold (1.16 log units) below what was measured, outside the stated range (above it).
By their numbers in this assay, from the lowest: compounds 2 and 1 (each within the scatter of the next); then compound 4. At a limit, above all of these: compound 3.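

At the amide-type nitrogen in the ring, the substituent does matter in this assay: isopropyl and cyclopentyl are not separated, but cyclohexyl stands apart from both, with a 14-fold higher number from compound 2 to compound 4 (1.14 log units; beyond the scatter) and with a 9.7-fold higher number from compound 1 to compound 4 (0.99 log units; beyond the scatter). Going by these compounds alone, the tolerance suggested by the first exchange at this nitrogen therefore holds for compound 1 and compound 2 but does not extend to compound 4, so the response here is not uniform across the three carbon-only substituents. Nothing in the data at hand gives a cause for this step.

As far as these compounds go, whether the higher number follows from the six-membered ring as such or from the larger carbon substituent stays open, and cyclobutyl, tert-butyl or a longer chain such as n-hexyl on this nitrogen would bear on that question. Also open, from the compounds shown here alone, is whether a ring carrying an oxygen, such as tetrahydropyranyl, behaves like cyclohexyl or like cyclopentyl, and whether any group on this nitrogen gives a number clearly lower than those of compound 1 and compound 2.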